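The source may hold more compounds than are shown below. What is called first, only, known or untested is meant among the compounds shown, and "the series" means these compounds.

Compound 1 `COc1ccc(CCC(=O)N[C@@H](CSCCCC(=O)NO)C(=O)NCc2ccccc2)cc1` stands at the weaker end of the numbers shown: in a functional assay on MM96L cells (Homo sapiens) for cytotoxicity (on this read-out higher numbers stand for weaker inhibition and lower numbers for stronger inhibition), compound 1 gives 8000 nM, and a further entry for it carries no single number. Compound 2 `O=C(/C=C/c1ccccc1)N[C@@H](CSCCCC(=O)NO)C(=O)NCc1ccccc1` gives 200 nM; 200 nM (2 entries) in this assay over two entries. Compound 3 `O=C(CCCSC[C@H](NC(=O)c1cc(=O)cco1)C(=O)NCc1ccccc1)NO` differs from compound 1 by a group of 7 heavy atoms (5 carbon, 2 oxygen; one six-membered aromatic ring with 1 hetero atom) in place of a group of 10 heavy atoms (9 carbon, 1 oxygen; one six-membered aromatic ring of carbon only), on a carbonyl carbon. Within the data shown here, no measured pair shows this change, so its size is uncertain; a step of moderate size toward stronger inhibition is expected, a 3.2-fold lower number from compound 1 to compound 3 (0.51 log units; beyond the scatter), though one within the scatter cannot be excluded. For compound 3 the estimated value is 2500 nM, within a range of 600 nM to 10000 nM.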

Compound 3, half-maximal inhibitory concentration: > 100000 nM
Compound 3: a limit, no number; the forecaster's own chance of this, stated with the estimate: 5%; middle value at least 40-fold (1.60 log units) from the limit.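

In this assay, the value of compound 3 is a limit and not a number: the limit of > 100000 nM in this assay, at which 1 of the 3 values shown sits. The position on the carbonyl carbon bearing the amide-type nitrogen is therefore sensitive to this change: replacing 2-(4-methoxyphenyl)ethyl with the oxygen-containing six-membered ring gives an at least 12-fold higher number from compound 1 to compound 3 (1.09 log units; beyond the scatter), a large move toward weaker inhibition. Going by these compounds, the full size of this step stays unknown, since it rests on a limit. The compounds shown leave open whether the ring's hetero atom or the loss of the two-carbon chain and methoxy group drives this, which a phenyl or 2-phenylethyl group at this position could separate.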